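This account rests on a few compounds, and the source may have more. Where it says the series, first, only, none or still open, it means among the compounds named here.

Values measured so far in a physicochemical assay for lipophilicity (on this read-out lower numbers stand for lower lipophilicity and higher numbers for higher lipophilicity), are these:
compound 1 `C[C@H]1CC[C@@H]2[C@@H](OC(=O)[C@]23CC(c2ccccc2F)=NO3)[C@]2(C)C(=O)C=C[C@@]12O` gives 1.58
compound 2 `Cc1ccc(C2=NO[C@]3(C2)C(=O)O[C@@H]2[C@H]3CC[C@H](C)[C@]3(O)C=CC(=O)[C@@]23C)cc1` gives 1.86
compound 3 `COc1ccc(C2C[C@@]3(ON2c2ccccc2)C(=O)O[C@@H]2[C@H]3CC[C@H](C)[C@]3(O)C=CC(=O)[C@@]23C)cc1` gives 3.25

Compound 3 stands highest of the three, with 3.25 on this read-out. Compound 2 at 1.86 and compound 1 at 1.58 both lie under it, beyond the scatter.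

Compound 4 `C[C@H]1CC[C@@H]2[C@@H](OC(=O)[C@]23CC(c2cccc(F)c2)N(c2ccccc2)O3)[C@]2(C)C(=O)C=C[C@@]12O` has not yet been measured. The change leading to it from compound 3 is 3-fluorophenyl in place of 4-methoxyphenyl on a saturated ring carbon and it puts 3-fluorophenyl in place of 4-methoxyphenyl on a saturated ring carbon, next to the ring nitrogen.

Among the compounds with values here, only one measured step swaps one substituted phenyl for another, and it is a number 0.28 log units higher from compound 1 to compound 2 (within the scatter) with 4-methylphenyl in place of 2-fluorophenyl on a carbon with a double bond to nitrogen. Within the data shown here, that is a single case at another place, and no measured step touches the saturated ring carbon, so it is a loose guide. Resting on a number 0.28 log units higher from compound 1 to compound 2 (within the scatter) alone, no step beyond the scatter is expected in this assay for this swap.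

The estimated step is a number 0.05 log units lower from compound 3 to compound 4 (within the scatter) and it is expected to stay within the scatter. For compound 4 the expected value is 3.2 with an estimated range from 2.75 to 3.65 on this read-out.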

Compound 4, partition coefficient: 3.35
Compound 4: the middle estimate sits 0.15 log units below what was measured; low and high end bracket the measured number.
By their numbers in this assay, from the lowest: compounds 1 and 2 (each within the scatter of the next); then compounds 3 and 4 (each within the scatter of the next).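

In this assay, 3-fluorophenyl in place of 4-methoxyphenyl on a saturated ring carbon, next to the ring nitrogen, gives a number 0.10 log units higher from compound 3 to compound 4 (within the scatter), so this position now has its first measured step and the read-out does not separate these two groups there. The change is not a trivial one by count, since the group that leaves has 1 hydrogen-bond acceptor and 8 heavy atoms, while the group that enters has 0 hydrogen-bond acceptors and 7 heavy atoms. Within the data shown here, until now the only swap of one substituted phenyl for another lay on a carbon with a double bond to nitrogen, and this second case, at a different place, also stays within the scatter; nothing available here explains why the two groups read alike.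

The compounds shown leave open whether a group other than a substituted phenyl at this saturated ring carbon, such as an amine, a carboxylic acid or a longer alkyl chain, would also stay within the scatter of compound 4. Among these compounds, they also leave open what happens when the phenyl group on the neighbouring ring atom is replaced, since no step touches it.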